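Shortening a Branched Chain on a Short-Lived Compound

The compounds below may be only part of what the source reports. "The series", "measured", "known", "first", "only" and "open" are said of these compounds alone.

Only compounds 1 and 2 have been tested in an in vitro ADME assay on microsomes from liver (Mus musculus) for metabolic stability; on this read-out lower numbers stand for a shorter-lived compound and higher numbers for a longer-lived compound. Compound 1, `CCC(CC)C(=O)N/C(=N/C1=NC(=O)C(=O)N1C(C)C)Nc1ccc(Cl)c(Cl)c1`, sits at one end of the range: in this assay compound 1 gives > 1 h, which is a limit of the assay rather than a measured number. Compound 2, `CCC(CC)C(=O)N/C(=N\C1=NC(=O)C(=O)N1c1ccc(Cl)c(Cl)c1)NC(C)C`, sits at the other end. In this assay compound 2 gives < 0.167 h, again a limit of the assay and not a number. The two values show a long-lived compound 1 and a short-lived compound 2, but their structures differ in several places, so no single change can be tied to that gap.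

Compound 3, `CC(C)N/C(=N/C1=NC(=O)C(=O)N1c1ccc(Cl)c(Cl)c1)NC(=O)C(C)C`, is not yet measured. It differs from compound 2 in one place: isopropyl in place of pentan-3-yl on a carbonyl carbon. The carbonyl and its amide-type nitrogen stay; only the branched chain on that carbonyl becomes shorter. No measured step of this kind exists among these compounds to lean on. The expected step is a step that the limit leaves unreadable from compound 2 to compound 3, small and not beyond the usual scatter. Compound 3 is thus expected to give 0.15 h, with a likely range from 0.05 h to 0.5 h.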

Compound 3, half-life: < 0.167 h
Compound 3: no number, only a limit; the forecaster's own chance of this, stated with the estimate: 55%; the middle value does not contradict the limit.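

Compound 2 and compound 3 both sit at the same limit of this assay, so no step can be read from one to the other: the limit of < 0.167 h in this assay, at which 2 of the 3 values shown sit. The compounds shown leave open how short-lived compound 2 and compound 3 really are, and so whether isopropyl in place of pentan-3-yl on a carbonyl carbon changes the half-life at all.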